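The source may hold more compounds than are shown below. What is called first, only, known or untested is meant among the compounds shown, and "the series" means these compounds.

Measured so far in a functional assay on SGC-7901 cells (Homo sapiens) for cytotoxicity, read by MTT assay, with a stated time of 72 h; a higher number here means a weaker inhibitor, a lower number a stronger inhibitor:
compound 1, `Oc1ccc(C2C/C(=N\NC(=S)N3CCOCC3)c3ccc(O)cc3O2)cc1`: 52200 nM
compound 2, `Oc1ccc(C2C/C(=N\NC(=S)N3CCCC3)c3ccc(O)cc3O2)cc1`: 37000 nM

Among the compounds with values here, compound 2 carries the smaller of the two numbers, but the single step recorded, a 1.4-fold lower number from compound 1 to compound 2 (0.15 log units; within the scatter), sits within the scatter, so compound 1 and compound 2 are not separated by these data.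

Compound 3, `Oc1ccc(C2C/C(=N\NC(=S)N3CCCCC3)c3ccc(O)cc3O2)cc1`, differs from compound 2 in one place: piperidin-1-yl in place of pyrrolidin-1-yl on a thiocarbonyl carbon. Within the data shown here, the only measured step that bears on this is the exchange of one ring amine on the thiocarbonyl carbon for another, a 1.4-fold lower number from compound 1 to compound 2 (0.15 log units; within the scatter), which did not move the number beyond the scatter. One step is a thin basis, yet nothing in it points to a change of size. The expectation for compound 3 is therefore a step of no more than the scatter, a 1.2-fold lower number from compound 2 to compound 3 (0.06 log units; within the scatter), in either direction. Compound 3 is estimated at 32000 nM, with a range from 13000 nM to 80000 nM.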

Compound 3, half-maximal inhibitory concentration: 40000 nM
For compound 3 the middle estimate is 1.3-fold (0.10 log units) below the measured one, and the stated range covers the measured number.
By their numbers in this assay, from the lowest: compounds 2, 3 and 1 (each within the scatter of the next).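

In this assay the exchange of the five-membered ring amine for the six-membered one gives a 1.1-fold higher number from compound 2 to compound 3 (0.03 log units; within the scatter) and the exchange of morpholin-4-yl for piperidin-1-yl gives a 1.3-fold lower number from compound 1 to compound 3 (0.12 log units; within the scatter) on the same thiocarbonyl carbon. With a third ring amine in hand, morpholin-4-yl, pyrrolidin-1-yl and piperidin-1-yl are not separated at this place, a statement that a single step could not support and that holds for these three groups only. No measurement here offers an explanation for this flat result.

From the compounds shown here alone, whether an open-chain amine such as diethylamino, or a piperazin-1-yl ring with its second nitrogen, would move the number beyond the scatter remains open. So does whether a step of that size can be reached at this place on the shared core at all.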